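The source may hold more compounds than are shown below. What is called first, only, known or untested is meant among the compounds shown, and "the series" means these compounds.

Compound 3, `COc1ccccc1C(=O)Nc1cccc(NC(=O)C2CC2)c1`, carries a cyclopropyl group on one of its two amide carbonyl carbons. In an in vitro functional assay on HEK293-A cells for antagonist activity at metabotropic glutamate receptor 5 (Rattus norvegicus), read by calcium flux (on this read-out higher numbers stand for weaker inhibition and lower numbers for stronger inhibition), compound 3 reaches only a limit of the assay, > 30000 nM, not a number. Two close relatives share its core. Compound 1, `COc1ccccc1C(=O)Nc1cccc(NC(=O)c2ccc(Cl)cc2)c1`, gives a limit of > 30000 nM in this assay. Compound 2, `COc1ccccc1C(=O)Nc1cccc(NC(=O)c2ccco2)c1`, gives a limit of > 30000 nM in this assay. The steps between them are therefore unreadable: a step that the two limits leave unreadable from compound 1 to compound 2, a step that the two limits leave unreadable from compound 1 to compound 3 and a step that the two limits leave unreadable from compound 2 to compound 3. All that is known is the limit of > 30000 nM in this assay, at which 3 of the 3 values shown sit.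

Compound 4, `COCC(=O)Nc1cccc(NC(=O)c2ccccc2OC)c1`, differs from compound 3 in one place: methoxymethyl in place of cyclopropyl on a carbonyl carbon. This is a fourth variation at the same carbonyl carbon. Because the limit of > 30000 nM in this assay, at which 3 of the 3 values shown sit, holds every value shown, nothing points to compound 4 escaping that limit. Compound 4 is expected to remain at the limit, with an estimate of 40000 nM and a range from 20000 nM to 100000 nM. The expected step is a step that the limit leaves unreadable from compound 3 to compound 4, meaning no change beyond the scatter is anticipated.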

Compound 4, half-maximal inhibitory concentration: > 30000 nM
Compound 4 gave a limit, no number; the forecaster's own chance of this, stated with the estimate: 85%; the middle value does not contradict the limit.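

Compound 4 gives only a limit, as do compound 1, compound 2 and compound 3, so no step among these four compounds can be read: the limit of > 30000 nM in this assay, at which 4 of the 4 values shown sit.

The compounds shown leave open whether any group on this carbonyl carbon gives a measurable inhibition in this assay.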